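The compounds below may be only part of what the source reports. "The series", "measured", "known", "first", "only" and "open" are said of these compounds alone.

Working notes on the series. In an ADME assay on BaF3 cells (Mus musculus) for cytotoxicity (a lower number here means that less compound is needed, a higher number that more compound is needed for the effect), the shared core is varied at the group carried on the aromatic nitrogen. Compound 1 `FC(F)(F)Oc1ccc(Nc2cc(-c3ccc4[nH]ccc4c3)ncn2)cc1` returns only a limit in this assay, > 10000 nM. Compound 2 `FC(F)(F)Oc1ccc(Nc2ncnc3nn(C4CCCCC4)cc23)cc1` likewise returns only a limit in this assay, > 10000 nM. For the measured compounds named here, compound 3 `NC(=O)Cn1ncc2c(Nc3ccc(OC(F)(F)F)cc3)ncnc21` is the one member with a number, giving 3300 nM in this assay. Compound 2 therefore stands where most of the series stands, at the limit of > 10000 nM in this assay, at which 2 of the 3 values shown sit; it is not placed against compound 3 beyond the observation that compound 3 gives a number and compound 2 does not.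

Compound 4 `OCCn1cc2c(Nc3ccc(OC(F)(F)F)cc3)ncnc2n1` is not yet measured in this assay. It differs from compound 2 by 2-hydroxyethyl in place of cyclohexyl on an aromatic nitrogen. Going by the values given here, no step between two measured compounds in this assay is available to calibrate this kind of change, so the expectation rests on the values as they stand: two limits and one number from compound 3. The step from compound 2 to compound 4 is expected to be an at least 1.1-fold lower number from compound 2 to compound 4 (0.04 log units; that floor lies within the scatter), that is none beyond the scatter, with the outcome most likely again a limit. Compound 4 is expected to give about 9000 nM in this assay, within a range from 3000 nM to 30000 nM.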

Compound 4, half-maximal effective concentration: > 10000 nM
Compound 4 gave a limit, no number; the forecaster's own chance of this, stated with the estimate: 60%; at least 1.1-fold (0.04 log units) between middle value and limit.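

In this assay compound 4 returns only a limit, > 10000 nM, as compound 2 does, so no step can be read between compound 2 and compound 4. The series stays largely at one value: the limit of > 10000 nM in this assay, at which 3 of the 4 values shown sit.

The compounds shown leave open what 2-hydroxyethyl in place of cyclohexyl on an aromatic nitrogen does to the number in this assay.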